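Three Aryl Variants Measured, a Fourth Awaiting a Number

The source may hold more compounds than are shown below. What is called first, only, known or untested is meant among the compounds shown, and "the series" means these compounds.

All three measured compounds share one core and differ only in the aryl group on a double-bonded chain carbon bound to a double-bonded chain carbon, and all were tested in a functional assay on HCT-116 cells (Homo sapiens) for inhibition, read by sulforhodamine B assay, with a stated time of 48 h, tested at 50 uM; a lower number here means less inhibition of growth, a higher number more inhibition of growth at the concentration tested:

compound 1, `COc1cc(/C=C/C(=O)/C=C/c2cccc3ccccc23)ccc1OCc1cn(CCCCCOc2cc(=O)oc3ccccc23)nn1`, gives 42%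
compound 2, `COc1cc(/C=C/C(=O)/C=C/c2cccs2)ccc1OCc1cn(CCCCCOc2cc(=O)oc3ccccc23)nn1`, gives 31%
compound 3, `COc1ccccc1/C=C/C(=O)/C=C/c1ccc(OCc2cn(CCCCCOc3cc(=O)oc4ccccc34)nn2)c(OC)c1`, gives 33%

Compound 3 stands second highest of the three numbers. Its nearest neighbour is compound 2, with a number 2 percentage points higher from compound 2 to compound 3 (within the scatter); the furthest is compound 1, with a number 9 percentage points lower from compound 1 to compound 3 (within the scatter). Only the swap a number 11 percentage points lower from compound 1 to compound 2 (beyond the scatter) reaches beyond the scatter, and that one is modest.

Compound 4, `COc1cc(/C=C/C(=O)/C=C/c2cc(OC)c(OC)c(OC)c2)ccc1OCc1cn(CCCCCOc2cc(=O)oc3ccccc23)nn1`, carries the change (3,4,5-trimethoxyphenyl in place of 2-methoxyphenyl on a double-bonded chain carbon bound to a double-bonded chain carbon). The two aryl swaps that start or end at compound 3 both stayed within the scatter, so another aryl swap at the same place is expected to move this assay little, in no sure direction. Compound 4 is therefore estimated at 37%, with a range from 22% to 54%. This estimate amounts to an expected step of a number 4 percentage points higher from compound 3 to compound 4 (within the scatter), which would stay within the scatter.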

Compound 4, percent growth inhibition at one concentration: 53%
Beside the measured number, compound 4's estimate is 16 percentage points below it, within the range that was stated.
By their numbers in this assay, from the lowest: compounds 2, 3 and 1 (each within the scatter of the next, the first and the last beyond it); then compound 4.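

The first three aryl groups suggested that this position mattered little, but in this assay the 3,4,5-trimethoxyphenyl group separates clearly from all of them, with a number 20 percentage points higher from compound 3 to compound 4 (beyond the scatter) and a number 22 percentage points higher from compound 2 to compound 4 (beyond the scatter) and a number 11 percentage points higher from compound 1 to compound 4 (beyond the scatter) as its steps. Compared with 2-methoxyphenyl, it has 12 heavy atoms rather than 8 and 3 hydrogen-bond acceptors rather than 1, so the aryl group on this double-bonded chain carbon can shift growth inhibition modestly. No measurement shown here accounts for the rise.

From the compounds shown here alone, it remains open whether a dimethoxyphenyl group would give a number like that of compound 4, and how an aminophenyl group would compare. These single-concentration numbers also leave open how the compounds would rank across a range of concentrations.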